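A few compounds are considered here, and "the series" means these few. Any claim that something is new, unique, unknown or untested is made for them only; others in the source may bear on it.

Compound 1 `CSc1nc2cnsc2n1[C@H]1C[C@H](O)[C@@H](CO)O1` and compound 2 `OC[C@H]1O[C@@H](n2c(SCc3ccccc3)nc3cnsc32)C[C@@H]1O` share a core and differ by phenyl in place of hydrogen on a saturated chain carbon bound to a sulfur. In a functional assay on KB cells (Homo sapiens) for antiproliferative activity (a lower number here means a stronger inhibitor, a higher number a weaker inhibitor), compound 1 gives > 100000 nM, which is a limit of the assay rather than a number. Compound 2 likewise gives > 100000 nM, also a limit. The step that the two limits leave unreadable from compound 1 to compound 2 therefore cannot be read, because of the limit of > 100000 nM in this assay, at which 2 of the 3 values shown sit. Compound 3 `CSc1nc2sncc2n1[C@H]1C[C@H](O)[C@@H](CO)O1` has the same atoms as compound 1, joined differently; the difference between the two cores is not broken down here. In this assay, going by the values given here, compound 3 gives 6000 nM, the only plain number among the three. Compound 4 `OC[C@H]1O[C@@H](n2c(SCc3ccccc3)nc3sncc32)C[C@@H]1O` is not yet measured and differs from compound 3 by phenyl in place of hydrogen on a saturated chain carbon bound to a sulfur, the same change as that between compound 1 and compound 2, at a place described in the same words. The earlier step left no readable size to lean on. The step of a 1.7-fold higher number from compound 3 to compound 4 (0.22 log units; within the scatter) is expected to be modest. Compound 4 is therefore estimated at 10000 nM, with a likely range from 2000 nM to 100000 nM.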

Compound 4, half-maximal inhibitory concentration: 3000 nM
The estimate for compound 4 lay 3.3-fold (0.52 log units) above the measured number, within the range that was stated.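

In this assay, replacing methylsulfanyl with benzylsulfanyl on the core of compound 3 gives a 2.0-fold lower number from compound 3 to compound 4 (0.30 log units; within the scatter), so on this core the added phenyl makes no difference beyond the usual scatter. The same change on the core of compound 1 cannot be read, because compound 1 and compound 2 both sit at a limit of the assay rather than at a number: the limit of > 100000 nM in this assay, at which 2 of the 4 values shown sit. The result therefore describes one core only and does not show whether the size of the step carries over to the other.

Only methyl and benzyl are shown at this place, on two cores. On these data alone, how a longer chain, an amine or a carboxylic acid would read there remains open.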